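Swapping one side group in a well-tolerated series

A few compounds are considered here, and "the series" means these few. Any claim that something is new, unique, unknown or untested is made for them only; others in the source may bear on it.

compound 1 `N#Cc1ccc(OC2CCN(C(=O)Nc3cc(-c4ccccn4)n[nH]3)CC2)cc1` gives > 64000 nM
compound 2 `O=C(Nc1cc(-c2ccccn2)n[nH]1)N1CCN(c2ccc(F)cc2)CC1` gives > 57000 nM
compound 3 `O=C(NCc1cccc(Cl)c1)Nc1cc(-c2ccccn2)n[nH]1` gives > 64000 nM

These three results come from an ADME assay on cells (Peritoneal macrophage cell, Mus musculus) for cytotoxicity, read by fluorescence and resazurin assay, with a stated time of 3 days (a higher number here means that more compound is tolerated, a lower number that less compound is tolerated), and each is a limit of the assay, not a number. Compound 1 sits at the limit of > 64000 nM in this assay, at which 2 of the 3 values shown sit, and so has only a limit. Compound 4 `O=C(Nc1cc(-c2ccccn2)n[nH]1)N1CCC(c2ccccc2)CC1` has phenyl in place of 4-cyanophenoxy on a saturated ring carbon and keeps the rest of compound 1. Among the measured compounds shown here, no measured pair shows a step, so no size can be read directly from this assay, and none beyond the scatter is expected. The expected change, an at least 1.0-fold lower number from compound 1 to compound 4 (0.02 log units; that floor lies within the scatter), stays within that scatter. This expectation leans on compound 2, whose limit is > 57000 nM despite its different structure. For compound 4 the estimated value is 60000 nM (30000 nM to 100000 nM).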

Compound 4, half-maximal cytotoxic concentration: > 64000 nM
Compound 4: no number, only a limit; the forecaster's own chance of this, stated with the estimate: 70%; middle value at least 1.0-fold (0.02 log units) from the limit.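

Compound 4 gives > 64000 nM, a limit and not a number. Among the compounds shown here, compound 1 also has only a limit, so no step from compound 1 to compound 4 can be read. The compounds shown leave open at what concentration any of them harms these cells.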